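Dimethylamino in place of cyclopropyl on a sulfonyl sulfur

A few compounds are considered here, and "the series" means these few. Any claim that something is new, unique, unknown or untested is made for them only; others in the source may bear on it.

In an ADME assay on Caco-2 cells (Homo sapiens) for permeability, in the apical to basolateral direction (a lower number here means that the compound crosses the layer more slowly, a higher number that the compound crosses the layer faster), compound 1 `CC(C)(C)OC(=O)N[C@H]1CCCCC/C=C\[C@@H]2C[C@@]2(C(=O)NS(=O)(=O)C2CC2)NC(=O)[C@@H]2C[C@@H](OC(=O)N3CCc4ccccc4C3)CN2C1=O` gives < 2 10^-6 cm/s, which is a limit and not a number. Compound 2 `CC(C)(C)OC(=O)N[C@H]1CCCCC/C=C\[C@@H]2C[C@@]2(C(=O)NS(=O)(=O)C2CC2)NC(=O)[C@@H]2C[C@@H](OC(=O)N3Cc4ccccc4C3)CN2C1=O` gives < 2 10^-6 cm/s, which is also a limit, so its position is known only as the limit of < 2 10^-6 cm/s in this assay, at which 2 of the 2 values shown sit. Compound 3 `CN(C)S(=O)(=O)NC(=O)[C@@]12C[C@H]1/C=C\CCCCC[C@H](NC(=O)OC(C)(C)C)C(=O)N1C[C@H](OC(=O)N3Cc4ccccc4C3)C[C@H]1C(=O)N2` differs from it by dimethylamino in place of cyclopropyl on a sulfonyl sulfur. Among the compounds with values here, the one measured step, a step that the two limits leave unreadable from compound 1 to compound 2, lies on a carbonyl carbon and gives no size to carry over. No change beyond the scatter is therefore expected, and no direction, for the estimated step that the limit leaves unreadable from compound 2 to compound 3. The estimate for compound 3 is 1 10^-6 cm/s, with an expected range of 0.4 10^-6 cm/s to 2.5 10^-6 cm/s.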

Compound 3, apparent permeability in the Caco-2 assay: < 2 10^-6 cm/s
Compound 3 gave a limit, no number; the forecaster's own chance of this, stated with the estimate: 85%; the middle value does not contradict the limit.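

In the Caco-2 assay, compound 2 gives < 2 10^-6 cm/s, which is a limit and not a number. In the Caco-2 assay, compound 3 gives < 2 10^-6 cm/s, which is also a limit. No step can be read between these two limits. The compounds shown leave open whether dimethylamino in place of cyclopropyl on a sulfonyl sulfur changes permeability at all. In a physicochemical assay for solubility, using the shake flask method, at pH 6.5 (on this read-out higher numbers stand for higher solubility and lower numbers for lower solubility), compound 2 gives 702 ug/mL and compound 3 gives 165 ug/mL, which is a 4.3-fold lower number from compound 2 to compound 3 (0.63 log units; beyond the scatter).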